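Swapping the sulfonamide nitrogen substituent on the shared core

The compounds below may be only part of what the source reports. "The series", "measured", "known", "first", "only" and "open" are said of these compounds alone.

Compound 1 `O=S(=O)(Nc1ncccn1)c1ccc(Nc2nncc3ccccc23)cc1` gives 67 nM
Compound 2 `O=S(=O)(Nc1nccs1)c1ccc(Nc2nncc3ccccc23)cc1` gives 77 nM

In a functional assay on HL-60 cells (Homo sapiens) for antiproliferative activity, read by sulforhodamine B assay, with a stated time of 72 h (on this read-out higher numbers stand for weaker inhibition and lower numbers for stronger inhibition), compound 2 stands level with compound 1 within the scatter. Compound 3 `Cc1cc(NS(=O)(=O)c2ccc(Nc3nncc4ccccc34)cc2)no1` keeps the shared core and differs from compound 2 on a sulfonamide nitrogen: 5-methyl-1,2-oxazol-3-yl in place of 1,3-thiazol-2-yl on a sulfonamide nitrogen. Within the data shown here, the one measured step at this place is a 1.1-fold higher number from compound 1 to compound 2 (0.06 log units; within the scatter), for 1,3-thiazol-2-yl in place of pyrimidin-2-yl. Among the measured compounds shown here, no measurement yet covers 5-methyl-1,2-oxazol-3-yl, so this single step is thin support. Nothing beyond the scatter is expected in this assay, and no direction is favoured. The expected step is a 1.1-fold higher number from compound 2 to compound 3 (0.04 log units; within the scatter). For compound 3 the estimated value is 85 nM, with an estimated range from 35 nM to 210 nM.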

Compound 3, half-maximal inhibitory concentration: 68 nM
The estimate for compound 3 lay 1.3-fold (0.10 log units) above the measured number, within the range that was stated.
By their numbers in this assay, from the lowest: compounds 1, 3 and 2 (each within the scatter of the next).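

In this assay 5-methyl-1,2-oxazol-3-yl on a sulfonamide nitrogen gives a 1.1-fold lower number from compound 2 to compound 3 (0.05 log units; within the scatter) and a 1.0-fold higher number from compound 1 to compound 3 (0.01 log units; within the scatter) against the two earlier groups. The level read-out at this position therefore extends to a third group, one that carries a methyl. No evidence at hand bears on the reason for this.

Still open, as far as these compounds go, is whether a plain phenyl, a simple alkyl chain or a chain ending in a carboxylic acid on this nitrogen would stay level. From the compounds shown here alone, the shared core itself also remains untested by these compounds.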